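Extending the Urea Toward a Hydroxyphenyl Semicarbazide

This account rests on a few compounds, and the source may have more. Where it says the series, first, only, none or still open, it means among the compounds named here.

Compound 1: `COc1cc(NC(C)CCCNC(=O)Nc2ccc(F)cc2)c2ncccc2c1`, 18000 nM
Compound 2: `COc1cc(NC(C)CCCNC(=O)Nc2cc(C(F)(F)F)cc(C(F)(F)F)c2)c2ncccc2c1`, 3500 nM

In a functional assay on L1210 cells (Mus musculus) for inhibition, read by MTT assay, with a stated time of 72 h (a higher number here means a weaker inhibitor, a lower number a stronger inhibitor), compound 1 gives the higher of the two numbers; compound 2 gives 3500 nM, a gap beyond the scatter. Compound 3 is `COc1cc(NC(C)CCCNC(=O)NNC(=O)Nc2ccc(O)cc2)c2ncccc2c1`, not yet measured. It differs from compound 1 by ((4-hydroxyphenyl)carbamoyl)amino in place of 4-fluorophenyl on an amide-type nitrogen. For the measured compounds named here, no measured pair shows this change, so its effect is unknown. Compound 3 is expected to stay close to compound 1, with a step of a 1.2-fold higher number from compound 1 to compound 3 (0.09 log units; within the scatter) that may be no more than the scatter. The estimate for compound 3 is 22000 nM, in a range from 7000 nM to 70000 nM.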

Compound 3, half-maximal inhibitory concentration: 95000 nM
Compound 3: middle estimate off by 4.3-fold (0.64 log units), on the low side, outside the stated range (above it).
By their numbers in this assay, from the lowest: compound 2; then compound 1; then compound 3.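

In this assay there is a 5.3-fold higher number from compound 1 to compound 3 (0.72 log units; beyond the scatter) when ((4-hydroxyphenyl)carbamoyl)amino replaces 4-fluorophenyl on an amide-type nitrogen, so this position does not accept every larger group without a loss of inhibition. Nothing available here accounts for that loss.

From the compounds shown here alone, whether the loss follows the added carbamoyl and amino units or the hydroxy group stays open, since the two enter together. Also open, going by these compounds, is how the same extended chain would behave if it ended in a 4-fluorophenyl, a 4-aminophenyl or a 4-carboxyphenyl group.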